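The source may report more compounds than this note shows. Statements on the series, on what has been measured and on what is new or still open speak of the compounds shown alone.

Compound 2 `COCc1nc(Br)c2cnnc(O)n12` is the starting point of this step. In a functional assay for inhibition, with Homo sapiens as the target (a lower number here means a stronger inhibitor, a higher number a weaker inhibitor), compound 2 gives only a limit of the assay, > 48000 nM, and not a number. Compound 1 `Cc1nc(Cc2ccccc2)n2c(O)nncc12` was run in this assay as well; in this assay compound 1 also gives only a limit, > 48000 nM. Among the compounds with values here, both results sit at the limit of > 48000 nM in this assay, at which 2 of the 2 values shown sit, so neither compound can be placed above or below the other, and no measured step connects them. Compound 3 `Oc1nncc2c(Br)nc(Cc3ccccc3)n12` is the compound to be measured. It differs from compound 2 by phenyl in place of methoxy on a saturated chain carbon bound to an aromatic carbon. Compound 1, which carries phenyl on that same chain carbon, gives only a limit, > 48000 nM. Compound 3 is therefore expected to give a value of about 60000 nM, with a range from 20000 nM to 200000 nM, and most likely again only a limit. The step from compound 2 to compound 3 is estimated as a step that the limit leaves unreadable from compound 2 to compound 3, no change beyond the scatter.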

Compound 3, half-maximal inhibitory concentration: > 48000 nM
Compound 3: a limit, no number; the forecaster's own chance of this, stated with the estimate: 85%; the middle value is on the limit's open side.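

In this assay, within the data shown here, compound 3 gives only a limit, > 48000 nM, so no step from compound 1 or compound 2 to compound 3 can be read: the limit of > 48000 nM in this assay, at which 3 of the 3 values shown sit. The compounds shown leave open whether phenyl in place of methoxy, or bromo in place of methyl, changes inhibition at all.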